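The source may hold more compounds than are shown below. What is called first, only, known or untested is meant among the compounds shown, and "the series" means these compounds.

In an ADME assay on MT4 cells (Homo sapiens) for cytotoxicity, read by MTT assay (a lower number here means that less compound is tolerated, a higher number that more compound is tolerated), three compounds sharing one core have been measured. Compound 1 `Cc1ccc(N(C(=O)c2ccccc2[N+](=O)[O-])C(=S)OCCN2C(=O)c3ccccc3C2=O)cc1` gives 100000 nM, compound 2 `Cc1ccc(N(C(=O)c2ccc(F)cc2F)C(=S)OCCN2C(=O)c3ccccc3C2=O)cc1` gives 20000 nM, and compound 3 `Cc1ccc(N(C(=O)c2cccc(Cl)c2Cl)C(=S)OCCN2C(=O)c3ccccc3C2=O)cc1` gives 35000 nM. Compound 3 cannot be told apart from compound 2, as the step of a 1.8-fold higher number from compound 2 to compound 3 (0.24 log units; within the scatter) stays within the scatter, and it is separated only from compound 1, by a 2.9-fold lower number from compound 1 to compound 3 (0.46 log units; beyond the scatter).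

Compound 4 `Cc1ccc(N(C(=O)c2c(Cl)cccc2Cl)C(=S)OCCN2C(=O)c3ccccc3C2=O)cc1` carries 2,6-dichlorophenyl in place of 2,3-dichlorophenyl on a carbonyl carbon. For the measured compounds named here, no measured step makes this exact kind of exchange. The nearest evidence is the swap of 2,4-difluorophenyl for 2,3-dichlorophenyl, a 1.8-fold higher number from compound 2 to compound 3 (0.24 log units; within the scatter). The modest steps, a 5.0-fold lower number from compound 1 to compound 2 (0.70 log units; beyond the scatter) and a 2.9-fold lower number from compound 1 to compound 3 (0.46 log units; beyond the scatter), both start from the 2-nitrophenyl group, which is not involved here, so they bear on it less directly. In this assay, no change beyond the scatter is therefore expected, and the estimated step is a 1.2-fold lower number from compound 3 to compound 4 (0.07 log units; within the scatter). For compound 4 the estimated value is 30000 nM, with an expected range of 13000 nM to 80000 nM.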

Compound 4, half-maximal cytotoxic concentration: 22000 nM
For compound 4 the middle estimate is 1.4-fold (0.13 log units) above the measured one, and the stated range covers the measured number.
By their numbers in this assay, from the lowest: compounds 2, 4 and 3 (each within the scatter of the next); then compound 1.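

In this assay the exchange of 2,3-dichlorophenyl for 2,6-dichlorophenyl on a carbonyl carbon stays within the scatter (a 1.6-fold lower number from compound 3 to compound 4 (0.20 log units; within the scatter)), so this rearrangement of the same atoms makes no readable difference here. Compound 4 also cannot be told apart from the 2,4-difluorophenyl compound (a 1.1-fold higher number from compound 2 to compound 4 (0.04 log units; within the scatter)), yet it is separated from the 2-nitrophenyl compound (a 4.5-fold lower number from compound 1 to compound 4 (0.66 log units; beyond the scatter)), which leaves compound 1 alone apart from compounds 2, 3 and 4, with none of the four going against this grouping. Nothing measured here offers a reason for this grouping.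

From the compounds shown here alone, whether an unsubstituted phenyl, a methoxyphenyl or an aminophenyl at this place would fall with compounds 2, 3 and 4 or with compound 1 remains open. Also open, going by these compounds, is whether a carboxylic acid on this ring would stand apart from both.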